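Swapping a Butyl Chain for Cyclopropyl on a Uracil Alkyne

The compounds below may be only part of what the source reports. "The series", "measured", "known", "first", "only" and "open" are said of these compounds alone.

Measured so far:
- compound 1, `CCCCC#Cc1c[nH]c(=O)[nH]c1=O`: 250000 nM
- compound 2, `CCCCCCC#Cc1cn([C@@H]2O[C@H](CO)[C@@H](O)[C@H]2O)c(=O)[nH]c1=O`: 87200 nM
- compound 3, `O=c1[nH]cc(C#CC(O)c2ccccc2)c(=O)[nH]1`: 237000 nM

Three compounds built on the same core were tested in an ADME assay on A549 cells (Homo sapiens) for cytotoxicity, read by MTT assay; a higher number here means that more compound is tolerated, a lower number that less compound is tolerated. Compound 1 gives the highest of the three numbers, with 250000 nM. Compound 3 sits closest to it; its value of 237000 nM lies within the scatter of compound 1, so the two cannot be told apart. Compound 2, with 87200 nM, is the only one that falls beyond the scatter below compound 1, so it is tolerated at lower concentration than compound 1.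

Compound 4, `O=c1[nH]cc(C#CC2CC2)c(=O)[nH]1`, has not yet been measured in this assay. It differs from compound 1 in one place: cyclopropyl in place of butyl on a triple-bonded carbon. A chain with no ring leaves and a three-membered non-aromatic ring of carbon only enters, while donors, acceptors and charge stay unchanged.

For the measured compounds named here, no measured pair shows this kind of step, so its size is unknown. Given that compound 1 and compound 3 differ on the triple-bonded carbon yet sit together in this assay, the change is expected to give no step beyond the scatter, a 1.0-fold lower number from compound 1 to compound 4 (0.02 log units; within the scatter). Compound 4 is therefore estimated at 240000 nM, within a range from 120000 nM to 480000 nM.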

Compound 4, half-maximal cytotoxic concentration: 251000 nM
Estimate against measurement, compound 4: 1.0-fold (0.02 log units) below; low and high end bracket the measured number.
By their numbers in this assay, from the lowest: compound 2; then compounds 3, 1 and 4 (each within the scatter of the next).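

For the compounds shown here, on a triple-bonded carbon of the shared core, the swap of butyl for cyclopropyl gives the first one-place comparison in this assay. The step is a 1.0-fold higher number from compound 1 to compound 4 (0.00 log units; within the scatter) and stays within the scatter, so this position takes a three-membered non-aromatic ring of carbon only in place of a chain with no ring without a measurable change in how much compound the cells tolerate. No measured evidence here explains why the two groups read alike.

Going by these compounds, whether an amine or a carboxylic acid at the end of the alkyne would also leave the number unchanged remains open. One step also cannot tell whether the same swap would read alike on a differently substituted core.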